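Compound 3 to compound 4: the 4-bromophenyl exchange

This account rests on a few compounds, and the source may have more. Where it says the series, first, only, none or still open, it means among the compounds named here.

In a functional assay (aorta) with Oryctolagus cuniculus as the target (a lower number here means tighter binding, a higher number weaker binding), compound 1 (`COc1cc(C(C)O)ccc1OCCCN1CCC(C(c2ccc(F)cc2)c2ccc(F)cc2)CC1`) gives 10 nM and compound 2 (`COC(=O)c1ccc(OCCCN2CCC(C(c3ccc(F)cc3)c3ccc(F)cc3)CC2)c(OC)c1`) gives 1.26 nM in the same read-out. Compound 3 (`COc1cc(OCCCN2CCC(C(c3ccc(F)cc3)c3ccc(F)cc3)CC2)ccc1C(C)=O`) gives 3.16 nM as the middle of the three numbers. Compound 4 (`Fc1ccc(C(c2ccc(F)cc2)C2CCN(CCCOc3ccc(Br)cc3)CC2)cc1`) carries 4-bromophenyl in place of 4-acetyl-3-methoxyphenyl on an oxygen on a saturated carbon. Measured changes at that place were modest, with a 2.5-fold higher number from compound 2 to compound 3 (0.40 log units; beyond the scatter) and a 3.2-fold lower number from compound 1 to compound 3 (0.50 log units; beyond the scatter) both beyond the scatter. For the measured compounds named here, no measured compound carries bromine, and no direction is firmly supported. No step beyond the scatter is expected in this assay here. Compound 4 is estimated at 4 nM with an expected range from 1.3 nM to 13 nM in this read-out. That estimate means an expected 1.3-fold higher number from compound 3 to compound 4 (0.10 log units; within the scatter) overall.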

Compound 4, dissociation constant: 1.59 nM
Compound 4: middle estimate off by 2.5-fold (0.40 log units), on the high side, within the range that was stated.
By their numbers in this assay, from the lowest: compounds 2, 4 and 3 (each within the scatter of the next, the first and the last beyond it); then compound 1.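

In this assay there is a 2.0-fold lower number from compound 3 to compound 4 (0.30 log units; within the scatter) and a 1.3-fold higher number from compound 2 to compound 4 (0.10 log units; within the scatter) so the bare 4-bromophenyl, with no hydrogen-bond acceptors, stays within the scatter of both compound 3 and compound 2. The methoxy and carbonyl groups on that ring are therefore not required for numbers in this range. Only the 4-(1-hydroxyethyl)-2-methoxyphenyl of compound 1 stands apart, with a 6.3-fold lower number from compound 1 to compound 4 (0.80 log units; beyond the scatter) in the same direction as its steps to compound 2 and compound 3.

Open, as far as these compounds go, is whether an amine or a carboxylic acid in place of the bromine keeps numbers in this range. Nothing at hand gives a reason for any of these steps.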